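The source may hold more compounds than are shown below. What is called first, only, known or untested is meant among the compounds shown, and "the series" means these compounds.

Measured in an assay on CHO cells for binding affinity to 5-hydroxytryptamine receptor 1B (Homo sapiens); a higher number here means a weaker inhibitor, a lower number a stronger inhibitor:
compound 1 `OCCC(NC1CCN(CCCc2c[nH]c3ccc(-n4cnnc4)cc23)CC1)c1ccccc1` gives 150 nM
compound 2 `NC(=O)OC[C@H](NC1CCN(CCCc2c[nH]c3ccc(-n4cnnc4)cc23)CC1)c1ccccc1` gives 120 nM
compound 3 `CC#CCN(C)C1CCN(CCCc2c[nH]c3ccc(-n4cnnc4)cc23)CC1` gives 81 nM

All three compounds share one core and differ only in the substituent on the amine nitrogen of the saturated ring. Compound 2 sits in the middle of the three numbers, and each of its neighbours lies within the scatter of it: the step from compound 1 to compound 2 is a 1.3-fold lower number from compound 1 to compound 2 (0.10 log units; within the scatter), and the values of compound 2 and compound 3 differ by even less than the step from compound 1 to compound 3, which is a 1.9-fold lower number from compound 1 to compound 3 (0.27 log units; within the scatter).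

Compound 4 `CC(=O)Nc1ccc([C@@H](C)NC2CCN(CCCc3c[nH]c4ccc(-n5cnnc5)cc34)CC2)cc1` is obtained from compound 2 by 1-(4-acetamidophenyl)ethyl in place of 2-(carbamoyloxy)-1-phenylethyl on an amine nitrogen. Both measured steps bear on this change, since each also swaps the group on that amine nitrogen, and neither moved the number beyond the scatter. The change to compound 4 is of the same kind, so no step beyond the scatter is expected in this assay, and the estimated step from compound 2 to compound 4 is no change at the digits printed from compound 2 to compound 4 (within the scatter). Compound 4 is therefore expected to give about 120 nM, with a range from 50 nM to 300 nM.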

Compound 4, half-maximal inhibitory concentration: 350 nM
For compound 4 the middle estimate is 2.9-fold (0.46 log units) below the measured one; the whole stated range lies below it.
By their numbers in this assay, from the lowest: compounds 3, 2 and 1 (each within the scatter of the next); then compound 4.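

In this assay, the group on an amine nitrogen whose other neighbour is a saturated ring carbon is no longer seen only to shift the number within the scatter: 1-(4-acetamidophenyl)ethyl brings a 2.9-fold higher number from compound 2 to compound 4 (0.46 log units; beyond the scatter) in place of 2-(carbamoyloxy)-1-phenylethyl, and a 2.3-fold higher number from compound 1 to compound 4 (0.37 log units; beyond the scatter) in place of 3-hydroxy-1-phenylpropyl, both modest steps. The group leaving compound 2 and the group entering compound 4 match in heavy atoms, in their single six-membered aromatic ring of carbon only and in their defined stereocentre, so a step beyond the scatter can arise here without any change in those counts. Nothing measured here accounts for the higher number of compound 4.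

The swap alters two parts of the group at once, so the compounds shown do not separate the effect of the acetamido group on the phenyl ring from that of replacing the carbamoyloxy-bearing chain with a plain ethyl link. A 1-phenylethyl group with an unsubstituted ring would bear on that split, and a 1-(4-aminophenyl)ethyl group or the opposite stereocentre would test how much of the step rests on the acetamido group or on the spatial arrangement.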